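A ring methyl shifts the cyclic aminopyrimidine agonist's potency

The compounds below may be only part of what the source reports. "The series", "measured", "known", "first", "only" and "open" are said of these compounds alone.

Measured so far:
compound 1 `CCc1cnc(N2CCC(n3ncc4cc(-c5ccc(S(C)(=O)=O)cc5)ccc43)CC2)nc1` in a functional assay on HEK293 cells for agonist activity at Glucose-dependent insulinotropic receptor (Homo sapiens), read by HTRF and cAMP accumulation, with a stated time of 30 min; on this read-out higher numbers stand for an effect only at larger amounts of compound and lower numbers for an effect already at smaller amounts: 14 nM
compound 2 `CCc1cnc(N2CCC(n3ncc4cc(-c5ccc(S(C)(=O)=O)cc5)c(C)cc43)CC2)nc1` in this assay: 70 nM

Compound 1 gives the lowest of the two numbers, and its closest neighbour is compound 2, reached by a 5.0-fold higher number from compound 1 to compound 2 (0.70 log units; beyond the scatter) after methyl in place of hydrogen on an aromatic carbon of the shared core.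

Compound 3 `CCc1cnc(N2CCC(n3ncc4c(C)c(-c5ccc(S(C)(=O)=O)cc5)ccc43)CC2)nc1` is not yet measured. It differs from compound 1 by methyl in place of hydrogen on an aromatic carbon. Among the measured compounds shown here, the only measured step that bears on it is a 5.0-fold higher number from compound 1 to compound 2 (0.70 log units; beyond the scatter), a methyl placed elsewhere on the same core, which weakened the effect by a modest but clear amount. On that basis a step of similar direction is expected in this assay, though the new site is a different one and the size is uncertain; the estimate is a 3.6-fold higher number from compound 1 to compound 3 (0.55 log units; beyond the scatter).

For compound 3 the expected value in this assay is 50 nM, with a range from 15 nM to 200 nM.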

Compound 3, half-maximal effective concentration: 3420 nM
The estimate for compound 3 lay 68-fold (1.84 log units) below the measured number, outside the stated range (above it).
By their numbers in this assay, from the lowest: compound 1; then compound 2; then compound 3.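

In this assay, the step of a 240-fold higher number from compound 1 to compound 3 (2.39 log units; beyond the scatter) shows that a hydrogen on this aromatic carbon, ortho to the 4-(methylsulfonyl)phenyl group and ortho to a fused ring, can hardly be replaced by methyl without a large loss of effect. Set beside a 5.0-fold higher number from compound 1 to compound 2 (0.70 log units; beyond the scatter) for the other methyl, it also shows that the same single-carbon change has a very different cost at different sites on the shared core, so the modest earlier step says little about this one. Nothing given here accounts for the size of this loss.

Going by these compounds, whether the loss belongs to methyl alone or to any replacement of hydrogen on this carbon remains open, as a fluorine or a methoxy group there would show. Also open, on these data alone, is whether it persists when a nitrile replaces the methylsulfonyl group on the phenyl ring.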